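This account rests on a few compounds, and the source may have more. Where it says the series, first, only, none or still open, it means among the compounds named here.

The measured compounds and their values:

compound 1, `Cc1cc(NCc2ccc3ccccc3n2)n2nc(C)c(-c3ccccc3)c2n1`, < 5000 nM
compound 2, `COc1ccc(-c2c(C)nn3c(NCc4ccccn4)cc(C)nc23)cc1`, < 5000 nM
compound 3, `COc1ccc(-c2cnn3c(NCc4ccccn4)cc(C)nc23)cc1`, < 5000 nM

In a physicochemical assay for solubility, read by HPLC, using the shake flask method, measured as kinetic solubility, with a stated time of 2 h, at pH 7.4 (a higher number here means a more soluble compound, a lower number a less soluble compound), compound 3 gives only a limit, < 5000 nM. Compound 2 likewise sits at a limit in this assay, < 5000 nM. Compound 1 too reports a limit there, < 5000 nM. All three values rest at the limit of < 5000 nM in this assay, at which 3 of the 3 values shown sit, so the step that the two limits leave unreadable from compound 2 to compound 3 cannot be read. Compound 4, `Cc1cc(NCc2ccccn2)n2ncc(-c3ccccc3F)c2n1`, differs from compound 3 by 2-fluorophenyl in place of 4-methoxyphenyl on an aromatic carbon. For the measured compounds named here, no measured step gives a readable size for such a change, and no step bears on the 2-fluorophenyl group itself. Compound 4 is therefore expected in this assay at 2000 nM, with a range from 300 nM to 8000 nM. The expected step is a step that the limit leaves unreadable from compound 3 to compound 4, and a further limit report is considered likely.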

Compound 4, solubility: 5000 nM
For compound 4 the middle estimate is 2.5-fold (0.40 log units) below the measured one, and the stated range covers the measured number.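

At this place, on an aromatic carbon of the five-membered aromatic ring, 2-fluorophenyl in place of 4-methoxyphenyl gives a number no lower from compound 3 to compound 4 (the limit leaves the size open) in this assay. Compound 4 is the only compound shown with a number rather than a limit: the limit of < 5000 nM in this assay, at which 3 of the 4 values shown sit. The step alone does not separate the entering fluorine from the leaving methoxy group.

The compounds shown leave open how far compound 3 lies from compound 4. They also leave open how a phenyl carrying an amine or a carboxylic acid at this place would read in this assay.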